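The source may report more compounds than this note shows. Statements on the series, on what has been measured and on what is new or still open speak of the compounds shown alone.

Series notes. Compound 1 `ClCc1cccc(Cn2cnc3c(Cl)ncnc32)c1` gives 3460 nM in a functional assay on NCI-H322M cells (Homo sapiens) for cytotoxicity, read by sulforhodamine B assay, with a stated time of 48 h; a higher number here means a weaker inhibitor of growth, a lower number a stronger inhibitor of growth. Compound 2 `ClCc1cccc(Cn2cnc3c(Cl)nc(Cl)nc32)c1` gives 5120 nM in this assay; it differs from compound 1 by chloro in place of hydrogen on an aromatic carbon, and the step is a 1.5-fold higher number from compound 1 to compound 2 (0.17 log units; within the scatter). Compound 3 `ClCc1ccccc1Cn1cnc2ncnc(Cl)c21` is built from the same atoms as compound 1, joined differently; the difference between the two cores is not broken down here. In this assay compound 3 gives 15800 nM, the highest number of the three measured compounds. Compound 4 `ClCc1ccccc1Cn1cnc2nc(Cl)nc(Cl)c21` is not yet measured; it differs from compound 3 by chloro in place of hydrogen on an aromatic carbon, the same change as that from compound 1 to compound 2, at a place described in the same words. The step from compound 3 to compound 4 is expected to be small, like a 1.5-fold higher number from compound 1 to compound 2 (0.17 log units; within the scatter), namely a 1.4-fold higher number from compound 3 to compound 4 (0.14 log units; within the scatter). Compound 4 is expected to give about 22000 nM in this assay, most likely between 10000 nM and 48000 nM.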

Compound 4, concentration for total growth inhibition: 14500 nM
For compound 4 the middle estimate is 1.5-fold (0.18 log units) above the measured one; the measured number falls inside the stated range.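

In this assay, chloro in place of hydrogen on an aromatic carbon of the core of compound 3 gives a 1.1-fold lower number from compound 3 to compound 4 (0.04 log units; within the scatter). Set beside the earlier step, the change carries across these two cores with no difference that can be told apart: the same change on two cores in this assay, a 1.5-fold higher number (0.17 log units; within the scatter) from compound 1 to compound 2 and a 1.1-fold lower number (0.04 log units; within the scatter) from compound 3 to compound 4, 1.6-fold (0.21 log units) apart, within the scatter of two such steps. This rests on a single pair per core in a single cell line, and neither step lies beyond the scatter, so it does not show that the change would behave alike on any other core or in any other read-out.

Still open, going by these compounds, is whether an amine, a methoxy group or a longer chain between two ring nitrogen atoms would give a step beyond the scatter. Also open, on these data alone, is how a hydroxymethyl group in place of the chloromethyl group would read in this assay.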